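This account rests on a few compounds, and the source may have more. Where it says the series, first, only, none or still open, it means among the compounds named here.

Compound 3, `O=C(Nc1cccc(N2CCCC2=O)c1)C1CCCN(C(=O)c2cc(C(F)(F)F)cc(C(F)(F)F)c2)C1`, was tested in an ADME assay on PC-3 cells (Homo sapiens) for cytotoxicity, read by WST assay, tested at 100 uM (on this read-out lower numbers stand for less inhibition and higher numbers for more inhibition at the one concentration tested (going by the name of the read-out)), and gives 0%. On this number it stands level with compound 1, `O=C(Nc1cccc(Cc2ccccc2)c1)C1CCCN(C(=O)c2cc(C(F)(F)F)cc(C(F)(F)F)c2)C1`, which in this assay gives 0%; the two together are the lowest of the three numbers measured. Compound 2, `O=C(Nc1cccc(CN2CCCC2)c1)C1CCCN(C(=O)c2cc(C(F)(F)F)cc(C(F)(F)F)c2)C1`, gives 51% in this assay, and the step of a number 51 percentage points lower from compound 2 to compound 3 (beyond the scatter) is the only large one seen; the step of no change at the digits printed from compound 1 to compound 3 (within the scatter) shows that exchanging one neutral group for another at this position left the read-out where it was.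

Compound 4, `CSc1cccc(NC(=O)C2CCCN(C(=O)c3cc(C(F)(F)F)cc(C(F)(F)F)c3)C2)c1`, is not yet measured. It differs from compound 3 in a single place: methylsulfanyl in place of 2-oxopyrrolidin-1-yl on an aromatic carbon. Within the data shown here, the steps that bear on this change are no change at the digits printed from compound 1 to compound 3 (within the scatter) and a number 51 percentage points lower from compound 2 to compound 3 (beyond the scatter): both alter the same position of the shared core, and only the step that introduces or removes pyrrolidin-1-yl on a saturated chain carbon moves the read-out beyond the scatter, whereas the exchange of benzyl for 2-oxopyrrolidin-1-yl does not. Methylsulfanyl is, like benzyl and 2-oxopyrrolidin-1-yl, a group that carries no net charge, so the step of a number 5 percentage points higher from compound 3 to compound 4 (within the scatter) is expected to stay within the scatter. Compound 4 is therefore estimated to give 5% in this assay, with a range from 0% to 20%.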

Compound 4, a percentage reported as inhibition, at one concentration (the size of the read-out at that concentration, not a potency): 0%
The estimate for compound 4 lay 5 percentage points above the measured number; measured number inside the range.
By their numbers in this assay, from the lowest: compounds 1, 3 and 4 (each within the scatter of the next); then compound 2.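

In this assay, the exchange of 2-oxopyrrolidin-1-yl, with 6 heavy atoms and a five-membered non-aromatic ring, for methylsulfanyl, with 2 heavy atoms and no ring, gives no change at the digits printed from compound 3 to compound 4 (within the scatter) and so adds a group without a ring to the low end of the series. The comparison with benzyl, which gives no change at the digits printed from compound 1 to compound 4 (within the scatter) at the same place, shows that three groups differing in atom count and ring type all read alike here. The exchange of (pyrrolidin-1-yl)methyl for methylsulfanyl gives a number 51 percentage points lower from compound 2 to compound 4 (beyond the scatter) and leaves compound 2 as the only one of the four set apart from the rest, but nothing measured here accounts for this.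

The compounds shown leave open whether the higher number of compound 2 follows from the pyrrolidine ring, from its nitrogen or from the carbon that links it to the aromatic ring. An aminomethyl group, a (dimethylamino)methyl group or a pyrrolidin-1-yl group placed directly on the aromatic carbon would each bear on this question.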